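A Chloro for Fluoro Swap at the Assay Limit

This account rests on a few compounds, and the source may have more. Where it says the series, first, only, none or still open, it means among the compounds named here.

In a functional assay on BT-549 cells (Homo sapiens) for antiproliferative activity, read by MTT assay, with a stated time of 48 h (on this read-out lower numbers stand for stronger inhibition and higher numbers for weaker inhibition), compound 1 (`CN1C(=O)C(O)(Cc2nnn[nH]2)c2ccccc21`) gives > 100000 nM as a limit of the assay and not a number. Compound 2 (`CN1C(=O)C(O)(Cc2nnn[nH]2)c2cc(F)ccc21`) likewise gives only > 100000 nM as a limit. Compound 3 (`O=C1N(Cc2ccc(Br)cc2)c2ccc(F)cc2C1(O)Cc1nnn[nH]1`) also gives > 100000 nM as a limit. Compound 2 therefore has no numerical position, and the two further values beside it are limits as well.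

Compound 4 (`CN1C(=O)C(O)(Cc2nnn[nH]2)c2cc(Cl)ccc21`) has not yet been measured. It carries chloro in place of fluoro on an aromatic carbon of compound 2 (chloro in place of fluoro on an aromatic carbon) and is otherwise unchanged.

For the measured compounds named here, two measured steps bear on this change. The closer one is a step that the two limits leave unreadable from compound 1 to compound 2 (fluoro in place of hydrogen on an aromatic carbon). The other is a step that the two limits leave unreadable from compound 2 to compound 3 (4-bromophenyl in place of hydrogen on a saturated chain carbon bound to an amide-type nitrogen in a ring). Going by the values given here, neither has a readable size, and the series so far offers only the limit of > 100000 nM in this assay, at which 3 of the 3 values shown sit, as its common reading. No step beyond the scatter is therefore expected in this assay for this swap. The expected change is a number no higher from compound 2 to compound 4 (the limit leaves the size open) and it is estimated to stay within the scatter. Compound 4 is estimated at 100000 nM with an expected range of 50000 nM to 200000 nM and may well prove to be only a limit.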

Compound 4, half-maximal inhibitory concentration: > 100000 nM
Compound 4 ended at the assay's limit; the forecaster's own chance of this, stated with the estimate: 85%; the middle value lies on the limit itself.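

In this assay compound 4 gives > 100000 nM, a limit of the assay and not a number. No new step can be read from compound 1 or compound 2 to compound 4, and the series stays at one reading: the limit of > 100000 nM in this assay, at which 4 of the 4 values shown sit.

The compounds shown leave open how hydrogen, fluoro and chloro on this aromatic carbon compare in this assay.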